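From 4-methoxyphenyl to pentan-3-yl on a shared core

A few compounds are considered here, and "the series" means these few. Any claim that something is new, unique, unknown or untested is made for them only; others in the source may bear on it.

Of the compounds shown here, three built on one shared core have been tested in an ADME assay on HepG2 cells (Homo sapiens) for cytotoxicity, read by luminescence, CellTiter-Glo and ATP content, with a stated time of 72 h; on this read-out lower numbers stand for an effect already at smaller amounts and higher numbers for an effect only at larger amounts of compound. Compound 1 `COc1ccc(F)cc1CNCCCNc1ccnc2cc(C3CCCCC3)ccc12` gives 2290 nM, compound 2 `COc1ccc(F)cc1CNCCCNc1ccnc2cc(CCC(C)C)ccc12` gives 890 nM, and compound 3 `COc1ccc(-c2ccc3c(NCCCNCc4cc(F)ccc4OC)ccnc3c2)cc1` gives 5960 nM, the highest of the three numbers. Compound 4 `CCC(CC)c1ccc2c(NCCCNCc3cc(F)ccc3OC)ccnc2c1` differs from compound 3 in one place: pentan-3-yl in place of 4-methoxyphenyl on an aromatic carbon. Among the measured compounds shown here, two measured steps bear on this change, read in reverse. a 2.6-fold higher number from compound 1 to compound 3 (0.42 log units; beyond the scatter) and a 6.7-fold higher number from compound 2 to compound 3 (0.83 log units; beyond the scatter), so moving away from 4-methoxyphenyl toward a group without a ring has given lower numbers, most strongly for isopentyl, which like pentan-3-yl carries no ring. A move to a lower number in this assay , beyond the scatter, is therefore expected, estimated as a 4.3-fold lower number from compound 3 to compound 4 (0.63 log units; beyond the scatter). Compound 4 is expected to give 1400 nM, within 500 nM to 3800 nM.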

Compound 4, half-maximal effective concentration in the HepG2 assay: 7860 nM
Compound 4: the middle estimate sits 5.6-fold (0.75 log units) below what was measured; measured number above the stated range.
By their numbers in the HepG2 assay, from the lowest: compound 2; then compound 1; then compounds 3 and 4 (each within the scatter of the next).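

In the HepG2 assay, replacing the 4-methoxyphenyl ring with a ring-free group at this aromatic carbon need not move the number at all (a 1.3-fold higher number from compound 3 to compound 4 (0.12 log units; within the scatter)). Having no ring is therefore no guide in itself, since in the HepG2 assay the two ring-free groups stand far apart (an 8.8-fold higher number from compound 2 to compound 4 (0.95 log units; beyond the scatter)) and cyclohexyl also gives a lower number (a 3.4-fold higher number from compound 1 to compound 4 (0.54 log units; beyond the scatter)). In a physicochemical assay for acid dissociation, compound 3 gives 9.47 and compound 4 gives 9.47 with no change, and no evidence at hand explains the gap between isopentyl and pentan-3-yl.

On these data alone, whether isopropyl or a longer unbranched chain would sit nearer isopentyl or pentan-3-yl stays open. So does the effect of an amine at the end of such a chain.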